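Cytotoxicity notes: from compound 2 to compound 3

The source may report more compounds than this note shows. Statements on the series, on what has been measured and on what is new or still open speak of the compounds shown alone.

In an ADME assay on HOS cells (Homo sapiens) for cytotoxicity (a lower number here means that less compound is tolerated, a higher number that more compound is tolerated), compound 1 `CN(Cc1nc2ccccc2n1CC1CCNC1)C1CCCc2cccnc21` gives 7700 nM as its reading. Compound 2 `CN(Cc1nc2ccccc2n1C[C@H]1CCCN(Cc2cccnc2)C1)[C@H]1CCCc2cccnc21` gives 2500 nM and so holds the lower of the two numbers, with a gap beyond the scatter. Compound 3 `CC(C)CN1CCC[C@H](Cn2c(CN(C)[C@H]3CCCc4cccnc43)nc3ccccc32)C1` carries isopropyl in place of pyridin-3-yl on a saturated chain carbon bound to an amine nitrogen in a ring and awaits measurement. Going by the values given here, no measured pair isolates this change, so no shift beyond the scatter is expected in this assay for now. The estimated move is a 1.2-fold higher number from compound 2 to compound 3 (0.08 log units; within the scatter) and stays small. For compound 3 the expected value is 3000 nM with an estimated range from 1200 nM to 7500 nM at this stage.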

Compound 3, half-maximal cytotoxic concentration: > 2000 nM
Compound 3: a limit, no number; the forecaster's own chance of this, stated with the estimate: 10%; the middle value does not contradict the limit.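

In this assay compound 3 gives > 2000 nM, a limit and not a number. Going by these compounds alone, no step from compound 2 to compound 3 can be read. The compounds shown leave open whether isopropyl in place of pyridin-3-yl shifts the reading at all.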